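A few compounds are considered here, and "the series" means these few. Any claim that something is new, unique, unknown or untested is made for them only; others in the source may bear on it.

Compound 3 `Cc1ccsc1[C@@H]1C[C@H](O)Cc2cc(OC(F)(F)F)ccc2N1` belongs to a set of three measured compounds that share one core. In an ADME assay on Vero cells (Chlorocebus sabaeus) for cytotoxicity (a higher number here means that more compound is tolerated, a lower number that less compound is tolerated), compound 3 gives 26700 nM. Compound 1 `Cc1ccsc1[C@@H]1C[C@H](O)Cc2cc(Cl)ccc2N1` gives 200000 nM, and compound 2 `Cc1ccc([C@@H]2C[C@H](O)Cc3cc(OC(F)(F)F)ccc3N2)s1` gives 23900 nM. On these numbers compound 3 stands far under compound 1 and close to compound 2: the step of a 7.5-fold lower number from compound 1 to compound 3 (0.87 log units; beyond the scatter) is the only one beyond the scatter, while the step of a 1.1-fold higher number from compound 2 to compound 3 (0.05 log units; within the scatter) lies within it.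

Compound 4 `O[C@@H]1Cc2cc(OC(F)(F)F)ccc2N[C@H](c2ccco2)C1` has not yet been measured. The change from compound 3 is furan-2-yl in place of 3-methylthiophen-2-yl on a saturated ring carbon. Among the measured compounds shown here, the one measured step at the same saturated ring carbon, a 1.1-fold higher number from compound 2 to compound 3 (0.05 log units; within the scatter), was within the scatter, and it is the only direct precedent; the step from compound 1 to compound 3 concerns the aromatic carbon and does not bear on this change. The expectation is therefore no step beyond the scatter, an estimated 1.1-fold lower number from compound 3 to compound 4 (0.03 log units; within the scatter). Compound 4 is expected to give about 25000 nM in this assay, with a range from 10000 nM to 60000 nM.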

Compound 4, half-maximal cytotoxic concentration: 166000 nM
Estimate against measurement, compound 4: 6.6-fold (0.82 log units) below; the measured number lies above the stated range.
By their numbers in this assay, from the lowest: compounds 2 and 3 (each within the scatter of the next); then compounds 4 and 1 (each within the scatter of the next).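

In this assay the saturated ring carbon next to the ring nitrogen now proves sensitive to the group it carries: the step of a 6.2-fold higher number from compound 3 to compound 4 (0.79 log units; beyond the scatter) and the step of a 6.9-fold higher number from compound 2 to compound 4 (0.84 log units; beyond the scatter) both lie beyond the scatter, whereas the two methylthiophene isomers had not separated. The change to furan-2-yl puts oxygen in place of sulfur in the aromatic ring and also removes the methyl group, and these compounds cannot show which of the two matters. Nothing available here accounts for the rise.

From the compounds shown here alone, an unsubstituted thiophen-2-yl on this carbon would separate the hetero atom from the methyl group, and that question stays open. Also open, going by these compounds, is whether furan-2-yl gives a step of this size with chloro in place of trifluoromethoxy on the aromatic carbon.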